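Hydroxy on Nitrogen: Compound 2 to Compound 3

The source may report more compounds than this note shows. Statements on the series, on what has been measured and on what is new or still open speak of the compounds shown alone.

Measured so far:
- compound 1, `O=C(O)c1ccc2cccc(O)c2[n+]1[O-]`: 16%
- compound 2, `Cc1cc(=O)c(O)c(C(=O)O)[nH]1`: 0%

In an assay on isolated protein for inhibition of methionine aminopeptidase 2 (Homo sapiens), read by fluorescence, tested at 200 uM (on this read-out lower numbers stand for less inhibition and higher numbers for more inhibition at the one concentration tested (going by the name of the read-out)), compound 1 gives 16%, while compound 2 gives 0%. Compound 2 thus stands lowest of the two numbers; the nearest is compound 1, whose number lies higher by an amount beyond the usual scatter. Among the compounds with values here, no step between measured compounds that differ in one place is available, so what the pair shows is only that the two values differ.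

Compound 3, `Cc1cc(=O)c(O)c(C(=O)O)n1O`, has not yet been measured in this assay. It differs from compound 2 by hydroxy in place of hydrogen on an aromatic nitrogen. The change sits on an aromatic nitrogen of a six-membered aromatic ring with one nitrogen, ortho to a carboxy group and ortho to a methyl group, meta to a hydroxy group.

Within the data shown here, with no measured step of this kind to lean on, the expectation for compound 3 rests on compound 2 alone, which gives 0%. A small upward step is expected, a number 10 percentage points higher from compound 2 to compound 3 (within the scatter), of a size that may not exceed the scatter. Compound 3 is accordingly estimated at 10% in this assay, within the range 0% to 30%.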

Compound 3, a percentage reported as inhibition, at one concentration (the size of the read-out at that concentration, not a potency): 32%
Estimate against measurement, compound 3: 22 percentage points below; the whole stated range lies below it.
By their numbers in this assay, from the lowest: compound 2; then compound 1; then compound 3.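

In this assay, hydroxy in place of hydrogen on an aromatic nitrogen gives a number 32 percentage points higher from compound 2 to compound 3 (beyond the scatter), and this is the only step shown between compounds that differ in one place. Where the earlier pair could show only that two values differ, this step ties a change in the read-out to a single place on the shared core: the aromatic nitrogen that stands ortho to a carboxy group and ortho to a methyl group. It also shows that the low end of the series is not fixed by the rest of the core, since compound 2 gives 0% and a single added hydroxy on that nitrogen is enough to lift the number beyond the scatter.

On these data alone, it remains open whether a methoxy group or an amine on the same nitrogen would give a step of similar size, and whether the step would survive if a longer chain such as ethyl took the place of the methyl group. Why the hydroxy has this effect also stays open, as nothing measured here speaks to the cause.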